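The compounds below may be only part of what the source reports. "The series", "measured", "known", "first", "only" and "open" are said of these compounds alone.

Measured compounds:
- compound 1, `COc1cc(C(=O)NNC(=S)Nc2csc(-c3ccccc3)c2)cc(OC)c1OC`: 39000 nM
- compound 2, `COc1ccc(-c2nnc(Nc3csc(-c4ccccc4)c3)s2)cc1`: 8000 nM
- compound 3, `COc1ccc(-c2nnc(Nc3csc(-c4ccc(C)cc4)c3)s2)cc1`: "not determined" (no result reported)

In a functional assay on A549 cells (Homo sapiens) for inhibition, read by colorimetric assay and MTT assay, with a stated time of 72 h (a higher number here means a weaker inhibitor, a lower number a stronger inhibitor), compound 1 gives 39000 nM, while compound 2 gives 8000 nM. Compound 3 carries a methyl on the phenyl that hangs off the thiophene, where compound 2 has none, but for compound 3 no number was obtained in this assay, so it cannot be placed among the other two on the numbers shown.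

Compound 4, `Cc1ccc(-c2cc(Nc3nnc(-c4ccc(O)cc4)s3)cs2)cc1`, is the next step. It differs from compound 3 in one place: hydrogen in place of methyl on an oxygen on an aromatic ring. In other words, the methoxy on the phenyl that sits on the shared core becomes a hydroxy, and the rest of the molecule is untouched.

Going by the values given here, no pair of measured compounds shows this particular change, and the nearest measured relative, compound 2, differs from compound 4 in two places rather than one. Without a measured step to lean on, the size of the change in this assay cannot be foreseen with confidence, and the most cautious expectation is a shift that stays within the usual scatter, in either direction. On that basis compound 4 is expected to give about 9000 nM in this assay, with a plausible range from 2000 nM to 40000 nM.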

Compound 4, half-maximal inhibitory concentration: 6000 nM
Compound 4: middle estimate off by 1.5-fold (0.18 log units), on the high side; measured number inside the range.
By their numbers in this assay, from the lowest: compounds 4 and 2 (each within the scatter of the next); then compound 1.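

In this assay compound 3 has no number shown, so the change from compound 3 to compound 4 gives no step that can be read. The compounds shown leave open how going from methoxy to hydroxy, on its own, moves the value in this assay. Nothing shown here bears on this result.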